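Acylated beta-lactone esters against fatty-acid amide hydrolase

This account rests on a few compounds, and the source may have more. Where it says the series, first, only, none or still open, it means among the compounds named here.

Compound 1, `CCCCCCCCCCC[C@@H](C[C@@H]1OC(=O)[C@H]1CCCCCC)OC(=O)[C@@H](N)CC(C)C`: > 50000 nM
Compound 2, `CCCCCCCCCCC[C@@H](C[C@@H]1OC(=O)[C@H]1CCCCCC)OC(=O)CCC(C)C`: 10400 nM
Compound 3, `CCCCCCCCCCC[C@@H](C[C@@H]1OC(=O)[C@H]1CCCCCC)OC(=O)CCNC=O`: > 50000 nM

Within the data shown here, in an assay on membranes from brain for inhibition of Fatty-acid amide hydrolase 1 (Rattus norvegicus) (a higher number here means a weaker inhibitor, a lower number a stronger inhibitor), compound 2 gives 10400 nM, the only plain number among the three measured compounds. For compound 1 this assay reports only a limit, > 50000 nM. For compound 3 this assay likewise reports only a limit, > 50000 nM. Among the measured compounds shown here, compound 2 therefore stands as the one compound whose inhibition could be quantified, while the other two sit at the limit of > 50000 nM in this assay, at which 2 of the 3 values shown sit.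

Compound 4, `CCCCCCCCCCC[C@@H](C[C@@H]1OC(=O)[C@H]1CCCCCC)OC(=O)[C@@H](NC(C)=O)C(C)CC`, has not yet been measured in this assay. It differs from compound 2 in one place: 1-acetamido-2-methylbutyl in place of isopentyl on a carbonyl carbon.

For the measured compounds named here, two measured steps bear on this change. Removing the amino group, an at least 4.8-fold lower number from compound 1 to compound 2 (0.68 log units; beyond the scatter), and introducing a formylamino group, an at least 4.8-fold higher number from compound 2 to compound 3 (0.68 log units; beyond the scatter), both show that a nitrogen-bearing substituent on this side chain goes with a higher number in this assay. Compound 4 carries an acetamido group at the same position, so a higher number than that of compound 2 is expected, of a size comparable to those steps, a 3.8-fold higher number from compound 2 to compound 4 (0.59 log units; beyond the scatter). Compound 4 is estimated at 40000 nM in this assay, within 15000 nM to 150000 nM, with a real chance that only a limit is returned.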

Compound 4, half-maximal inhibitory concentration: 6600 nM
Beside the measured number, compound 4's estimate is 6.1-fold (0.78 log units) above it; the whole stated range lies above it.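

In this assay, putting 1-acetamido-2-methylbutyl in place of isopentyl on this carbonyl carbon gives a 1.6-fold lower number from compound 2 to compound 4 (0.20 log units; within the scatter), so a nitrogen in this side chain does not by itself go with a higher number, as compounds 1 and 3 had suggested. Compound 4 instead stands apart from the two other nitrogen-bearing compounds, with an at least 7.5-fold lower number from compound 3 to compound 4 (0.87 log units; beyond the scatter) and an at least 7.5-fold lower number from compound 1 to compound 4 (0.87 log units; beyond the scatter). Both of those steps start from a limit of the assay and not from a plain number: the limit of > 50000 nM in this assay, at which 2 of the 4 values shown sit.

The steps to compound 4 do not settle whether the acetyl on the nitrogen or the shape of the branched chain accounts for its distance from compound 1, as the two differ in both features at once. As far as these compounds go, what a benzamido group, a carboxylic acid or a longer chain would give on this carbonyl carbon also remains open, as does the outcome of inverting the defined stereocentre that enters with the 1-acetamido-2-methylbutyl group.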